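The source may report more compounds than this note shows. Statements on the series, on what has been measured and on what is new or still open speak of the compounds shown alone.

Measured compounds in the series:

- compound 1, `CC(=O)Nc1ccc(-n2nncc2CN2C(=O)C3(C(C#N)=C(N)Oc4c(N)cc5nc6ccccc6nc5c43)c3ccccc32)cc1`: > 50000 nM
- compound 2, `CCOc1ccccc1-n1nncc1CN1C(=O)C2(C(C#N)=C(N)Oc3c(N)cc4nc5ccccc5nc4c32)c2ccccc21`: 30500 nM
- compound 3, `CCc1cccc(CC)c1-n1nncc1CN1C(=O)C2(C(C#N)=C(N)Oc3c(N)cc4nc5ccccc5nc4c32)c2ccccc21`: 16500 nM

In a functional assay on HepG2 cells (Homo sapiens) for antiproliferative activity, read by MTT assay, with a stated time of 48 h (a higher number here means a weaker inhibitor, a lower number a stronger inhibitor), compound 1 gives > 50000 nM, which is a limit of the assay rather than a number, as shown by the limit of > 50000 nM in this assay, at which 1 of the 3 values shown sits. Compound 2 gives 30500 nM and compound 3 gives 16500 nM. Compound 3 has the lowest of the two numbers, but the gap to its nearest neighbour, a 1.8-fold lower number from compound 2 to compound 3 (0.27 log units; within the scatter), sits within the scatter, so the two cannot be ordered. Going by the values given here, the one step that clears the scatter is an at least 3.0-fold lower number from compound 1 to compound 3 (0.48 log units; beyond the scatter), while an at least 1.6-fold lower number from compound 1 to compound 2 (0.21 log units; that floor lies within the scatter) rests on a floor that does not.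

Compound 4, `N#CC1=C(N)Oc2c(N)cc3nc4ccccc4nc3c2C12C(=O)N(Cc1cnnn1-c1ccc([N+](=O)[O-])cc1[N+](=O)[O-])c1ccccc12`, differs from compound 3 in one place: 2,4-dinitrophenyl in place of 2,6-diethylphenyl on an aromatic nitrogen. All three measured steps exchange the aryl group on the same aromatic nitrogen, and they span a narrow band, from a limit to the value of compound 3. Among the compounds with values here, no measured step brings in the 2,4-dinitrophenyl group, so its effect is unknown. The expectation for compound 4 is therefore a step of a 1.5-fold higher number from compound 3 to compound 4 (0.18 log units; within the scatter), that is no change beyond the scatter, with the band of the series as the range. Compound 4 is estimated at 25000 nM, between 9000 nM and 60000 nM.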

Compound 4, half-maximal inhibitory concentration: 18400 nM
The estimate for compound 4 lay 1.4-fold (0.13 log units) above the measured number; the range from low to high includes it.
By their numbers in this assay, from the lowest: compounds 3, 4 and 2 (each within the scatter of the next). At a limit, above all of these: compound 1.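

In this assay, the 2,4-dinitrophenyl group brings 4 hydrogen-bond acceptors where 2,6-diethylphenyl has 0, yet compound 4 cannot be separated from its neighbours: a 1.1-fold higher number from compound 3 to compound 4 (0.05 log units; within the scatter) and a 1.7-fold lower number from compound 2 to compound 4 (0.22 log units; within the scatter). Going by these compounds alone, this aryl position on the aromatic nitrogen therefore accepts a dinitro-substituted ring, a diethyl-substituted ring and an ethoxy-substituted ring with no order among compound 2, compound 3 and compound 4, while the one new step beyond the scatter is an at least 2.7-fold lower number from compound 1 to compound 4 (0.43 log units; beyond the scatter). Compound 1 remains a limit and not a number, so that step is only a floor: the limit of > 50000 nM in this assay, at which 1 of the 4 values shown sits.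

As far as these compounds go, it remains open whether an amine or a carboxylic acid on the aryl ring would move the number outside the band shared by compound 2, compound 3 and compound 4. Also open, from the compounds shown here alone, are what a phenyl ring carrying a single nitro group would give, and what a longer alkyl chain in place of the aryl group would do.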